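Benzyl ester to free acid in a purine-glycine amide series

The compounds below may be only part of what the source reports. "The series", "measured", "known", "first", "only" and "open" are said of these compounds alone.

Compound 2 `O=C(OCc1ccccc1)[C@@H]1CCCN1C(=O)CN(c1nc(Cl)nc2[nH]cnc12)C1CC1` and compound 1 `O=C(O)[C@@H]1CCCN1C(=O)CN(c1nc(Cl)nc2[nH]cnc12)C1CC1` share a core and differ by hydrogen in place of benzyl on an oxygen next to a carbonyl group. In a functional assay on the whole organism (Tail, strain ICR) with Mus musculus as the target, in the tail flick test, with a stated time of 90 min, at a dose of 25 umol/kg by the oral route (a higher number here means a stronger effect of the compound at the dose given, a lower number a weaker effect), compound 2 gives 43.3% and compound 1 gives 26%, a step of a number 17.3 percentage points lower from compound 2 to compound 1 (beyond the scatter). Compound 3 `CC(C)C[C@H](NC(=O)CN(c1nc(Cl)nc2[nH]cnc12)C1CC1)C(=O)OCc1ccccc1` carries a different core; the difference between the two cores is not broken down here. In this assay compound 3 gives 15.2%, the lowest of the three numbers. Compound 4 `CC(C)C[C@H](NC(=O)CN(c1nc(Cl)nc2[nH]cnc12)C1CC1)C(=O)O` is not yet measured and differs from compound 3 by hydrogen in place of benzyl on an oxygen next to a carbonyl group, the same change at the same place as from compound 2 to compound 1. The step is expected to run in the same direction but smaller, a number 9.2 percentage points lower from compound 3 to compound 4 (within the scatter), since compound 3 starts at 15.2% and leaves little room below it. Compound 4 is estimated at 6% in this assay.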

Compound 4, a percentage reported as activity, at one dose (the size of the read-out at that dose, not a potency): 27%
Estimate against measurement, compound 4: 21 percentage points below, outside the stated range (above it).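

Hydrogen in place of benzyl on an oxygen next to a carbonyl group gives, in this assay, a number 11.8 percentage points higher from compound 3 to compound 4 (beyond the scatter), and this direction does not match the one seen on the other core: the same change on two cores in this assay, a number 17.3 percentage points lower (beyond the scatter) from compound 2 to compound 1 and a number 11.8 percentage points higher (beyond the scatter) from compound 3 to compound 4, 29.1 percentage points apart, beyond the scatter of two such steps

The step measured on one core therefore did not carry over to the other, not even in sign. These two pairs show that the outcome differs with the core, but they do not show which part of the cores accounts for this or how the change would run on a third core.

Open, as far as these compounds go, is whether a methyl ester or a primary amide in place of the benzyl ester would follow either step. Also open, from the compounds shown here alone, is whether an amine in place of the chlorine would alter the steps on these two cores.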